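The source may hold more compounds than are shown below. What is called first, only, known or untested is meant among the compounds shown, and "the series" means these compounds.

Measured so far in an assay on isolated protein for inhibition of DNA topoisomerase 1 (Homo sapiens), tested at 100 uM; on this read-out higher numbers stand for a stronger effect at the one concentration tested and lower numbers for a weaker effect:
Compound 1 `Clc1ccc(-c2cc(-c3ccc(Cl)o3)cc(-c3cccs3)n2)cc1` gives 38.9%.
Compound 2 `Clc1ccc(-c2cc(-c3ccoc3)cc(-c3ccsc3)n2)cc1` gives 0%.
Compound 3 `Clc1ccc(-c2cc(-c3ccsc3)nc(-c3ccccn3)c2)o1` gives 0%.

Compound 3 stands level with compound 2 at the digits shown, and together they are the lowest of the three numbers; the reading of compound 3 in this assay does not differ from that of compound 2 within the usual scatter, while compound 1 lies clearly higher, a gap beyond the scatter. The step to compound 4 `Clc1ccc(-c2cc(-c3ccc(Cl)o3)cc(-c3ccsc3)n2)cc1` changes one group: 4-chlorophenyl in place of pyridin-2-yl on an aromatic carbon. Within the data shown here, no comparable step among the measured compounds exists, so its size is uncertain. A moderate rise is expected, and the estimated step is a number 18 percentage points higher from compound 3 to compound 4 (beyond the scatter). The estimate for compound 4 is 18%, between 0% and 45%.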

Compound 4, a percentage reported as inhibition, at one concentration (the size of the read-out at that concentration, not a potency): 29.8%
Beside the measured number, compound 4's estimate is 11.8 percentage points below it, and the stated range covers the measured number.
By their numbers in this assay, from the lowest: compounds 2 and 3 (each within the scatter of the next); then compounds 4 and 1 (each within the scatter of the next).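

In this assay, 4-chlorophenyl in place of pyridin-2-yl next to the ring nitrogen gives a number 29.8 percentage points higher from compound 3 to compound 4 (beyond the scatter), and 5-chlorofuran-2-yl in place of furan-3-yl gives a number 29.8 percentage points higher from compound 2 to compound 4 (beyond the scatter). Among these compounds, the reading therefore appears only when 4-chlorophenyl and 5-chlorofuran-2-yl are both present. Thiophen-3-yl in place of thiophen-2-yl gives a number 9.1 percentage points lower from compound 1 to compound 4 (within the scatter), so the two thiophene attachments cannot be told apart here.

On these data alone, whether plain phenyl or 4-aminophenyl at this position would keep the reading remains open. No supporting evidence explains these steps.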